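Adding Ethyl to a Weak Inhibitor's Short Chain

This account rests on a few compounds, and the source may have more. Where it says the series, first, only, none or still open, it means among the compounds named here.

In a functional assay on HeLa cells (Homo sapiens) for antiproliferative activity, read by MTT assay, with a stated time of 72 h (a higher number here means a weaker inhibitor, a lower number a stronger inhibitor), compound 1 `O=C(NCCCc1ccccc1)c1csc(NC(=S)Nc2ccc(Cl)cc2)n1` gives 32200 nM while compound 2 `CC(=O)NNC(=O)c1csc2ncc(-c3ccc(C)cc3)n12` gives 74200 nM and so stands as the weaker of the pair, by a gap beyond the usual scatter. Compound 3 `CCCC(=O)NNC(=O)c1csc2ncc(-c3ccc(C)cc3)n12` carries ethyl in place of hydrogen on a saturated chain carbon bound to a carbonyl carbon. Going by the values given here, no pair of measured compounds shows what such a change does. The expectation therefore stays anchored on compound 2 at 74200 nM as its closest relative. The expected 1.3-fold lower number from compound 2 to compound 3 (0.13 log units; within the scatter) is small, within the scatter, toward a lower number. Expected for compound 3 is 55000 nM with 22000 nM to 100000 nM as the range.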

Compound 3, half-maximal inhibitory concentration: 45600 nM
Beside the measured number, compound 3's estimate is 1.2-fold (0.08 log units) above it; the measured number falls inside the stated range.
By their numbers in this assay, from the lowest: compounds 1, 3 and 2 (each within the scatter of the next, the first and the last beyond it).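

Putting ethyl in place of hydrogen on a saturated chain carbon bound to a carbonyl carbon gives a 1.6-fold lower number from compound 2 to compound 3 (0.21 log units; within the scatter) in this assay. Going by these compounds alone, this is the first measured step at this position, and it shows that the position can carry ethyl with no change that stands clear of the scatter. No further measurement bears on this result.

Going by these compounds, what remains open is whether a longer chain, an amine or a carboxylic acid at this place would move the number beyond the scatter. A single step also cannot show whether ethyl would behave the same way on another core.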